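Moving a Methoxy Group Around the Phenyl Ring

The source may hold more compounds than are shown below. What is called first, only, known or untested is meant among the compounds shown, and "the series" means these compounds.

Measured compounds:
compound 1 `COc1ccccc1-c1cnc(NC(=O)c2ccc(F)cc2)n1C`, > 100000 nM;
compound 2 `COc1ccc(-c2cnc(NC(=O)c3cccc(OC)c3)n2C)cc1`, > 100000 nM;
compound 3 `Cn1c(-c2ccccc2)cnc1NC(=O)c1cccc(Cl)c1`, > 50000 nM.

In a toxicity assay on THP-1 cells (Homo sapiens) for inhibition (on this read-out lower numbers stand for higher toxicity in this test and higher numbers for lower toxicity in this test), compound 1 gives only a limit, > 100000 nM, not a number. Compound 2 likewise sits at a limit, > 100000 nM. Compound 3 sits at a limit as well, > 50000 nM. All three shown values are limits, so compound 1 cannot be placed above or below its neighbours; every measured compound simply reaches the limit of > 100000 nM in this assay, at which 2 of the 3 values shown sit, or the limit of > 50000 nM in this assay, at which 1 of the 3 values shown sits, without a measured toxicity.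

Compound 4 `COc1cccc(-c2cnc(NC(=O)c3ccc(F)cc3)n2C)c1` differs from compound 1 by 3-methoxyphenyl in place of 2-methoxyphenyl on an aromatic carbon. Within the data shown here, with no measured step on this change, no step beyond the usual scatter is expected in this assay, and compound 4 is expected to remain at the limit.

Compound 4 is therefore estimated at 150000 nM, between 50000 nM and 500000 nM. The expected step that the limit leaves unreadable from compound 1 to compound 4 is essentially none.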

Compound 4, half-maximal cytotoxic concentration: > 100000 nM
Compound 4 was reported as a limit (the forecaster's own chance of this, stated with the estimate: 85%); the middle value is on the limit's open side.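

Among these compounds, compound 1 and compound 4 are both reported only as limits in this assay, so no step between them can be read. The compounds shown leave open whether 3-methoxyphenyl in place of 2-methoxyphenyl changes toxicity at all.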